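Aryl Swap on the Imine Nitrogen of Compound 1

This account rests on a few compounds, and the source may have more. Where it says the series, first, only, none or still open, it means among the compounds named here.

Compound 1 `Cc1cccc(/N=C2/NC(=O)/C(=C/c3ccccn3)S2)c1` sits second highest of the three numbers in a functional assay on the whole organism (strain Swiss albino) for inhibition, with Mus musculus as the target, in the writhing test, with stated times of 30 min and 15 min, at a dose of 50 mg/kg by the oral route (on this read-out lower numbers stand for less inhibition and higher numbers for more inhibition at the one dose given (going by the name of the read-out)), where compound 1 gives 52.3%. Compound 2 `O=C1N/C(=N\Nc2ccccc2)S/C1=C\c1ccccn1` gives 46.2%, and compound 3 `O=C1N/C(=N/c2cccc([N+](=O)[O-])c2)S/C1=C\c1ccccn1` gives 62.3%. The only single-point step among these, a number 10 percentage points higher from compound 1 to compound 3 (within the scatter), stays within the scatter. Compound 4 `O=C1N/C(=N/c2ccccc2Cl)S/C1=C\c1ccccn1` differs from compound 1 by 2-chlorophenyl in place of 3-methylphenyl on a double-bonded nitrogen. Going by the values given here, no measured step exchanges one aryl group for another; the one step available shows that a change on that aromatic ring left the read-out within the scatter. The next step is therefore expected to stay within the scatter as well, estimated as a number 2.7 percentage points higher from compound 1 to compound 4 (within the scatter). Compound 4 is estimated at 55%, between 42% and 68%.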

Compound 4, a percentage reported as inhibition, in the whole organism at one dose (the size of the read-out at that dose, not a potency): 36.2%
Estimate against measurement, compound 4: 18.8 percentage points above; the measured number lies below the stated range.
By their numbers in this assay, from the lowest: compounds 4, 2, 1 and 3 (each within the scatter of the next, the first and the last beyond it).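

In this assay, 2-chlorophenyl in place of 3-methylphenyl on a double-bonded nitrogen gives a number 16.1 percentage points lower from compound 1 to compound 4 (beyond the scatter), the first single-place step shown that lies beyond the scatter. The read-out at this position can therefore respond to a change of aryl group, which a number 10 percentage points higher from compound 1 to compound 3 (within the scatter) did not show. Nothing available explains this step.

The step changes both the substituent and where it sits on the ring, and the compounds shown do not separate the two. Going by these compounds, it remains open how a 3-chlorophenyl group or an aminophenyl group would read out here.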